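N-methylation of the ring amide in two indolinone series

A few compounds are considered here, and "the series" means these few. Any claim that something is new, unique, unknown or untested is made for them only; others in the source may bear on it.

Working notes. The first pair shares one core: compound 1 `COc1cc2c(cc1C)NC(=O)/C2=C/c1c(Cl)n(C)c2cc(C)c(OC)cc12` and compound 2 `COc1cc2c(cc1C)N(C)C(=O)/C2=C/c1c(Cl)n(C)c2cc(C)c(OC)cc12`. In a functional assay on cells (Melanoma cell, Homo sapiens) for inhibition, with a stated time of 48 h (a lower number here means a stronger inhibitor of growth, a higher number a weaker inhibitor of growth), compound 1 gives 15100 nM, and compound 2 gives 16200 nM. The step between them, (methyl in place of hydrogen on an amide-type nitrogen in a ring), moved the read-out by a 1.1-fold higher number from compound 1 to compound 2 (0.03 log units; within the scatter), so within this core the methyl on the ring amide nitrogen left growth inhibition essentially unchanged.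

The second core is represented by compound 3 `CN(C)c1ccc2[nH]c(Cl)c(/C=C3/C(=O)Nc4ccc(O)cc43)c2c1`, which in this assay gives 5250 nM, the lowest number among the three measured compounds, with its gaps to compound 1 and compound 2 both beyond the scatter. How the core of compound 3 differs from the core of compound 1 is not broken down here.

The unmeasured compound 4 `CN(C)c1ccc2[nH]c(Cl)c(/C=C3/C(=O)N(C)c4ccc(O)cc43)c2c1` is made from compound 3 by methyl in place of hydrogen on an amide-type nitrogen in a ring. The place of the change is described in the same words as for the step from compound 1 to compound 2, so this is the same change, now applied to the second core. Within the data shown here, only one measured example of the change exists, and it sits on a different core, so the expectation rests on that single step.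

In this assay compound 4 is expected to land close to compound 3, with a step of about a 1.1-fold higher number from compound 3 to compound 4 (0.04 log units; within the scatter), which rests on the near-flat step a 1.1-fold higher number from compound 1 to compound 2 (0.03 log units; within the scatter) seen with the first core. The estimate for compound 4 is therefore 5800 nM, with a range from 2700 nM to 12500 nM to allow for the change of core.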

Compound 4, concentration for 50% growth inhibition: 4570 nM
Beside the measured number, compound 4's estimate is 1.3-fold (0.10 log units) above it; measured number inside the range.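

On the second core, methyl in place of hydrogen on an amide-type nitrogen in a ring gives a 1.1-fold lower number from compound 3 to compound 4 (0.06 log units; within the scatter) in this assay, so compound 4 stays level with compound 3, as compound 2 does with compound 1. The two steps agree: the same change on two cores in this assay, a 1.1-fold higher number (0.03 log units; within the scatter) from compound 1 to compound 2 and a 1.1-fold lower number (0.06 log units; within the scatter) from compound 3 to compound 4, 1.2-fold (0.09 log units) apart, within the scatter of two such steps. Within this series, then, the change carried from one core to the other as a flat step in growth inhibition, but two pairs in a single cell assay do not show that it would stay flat on a further core or in another read-out, and they give no reason for the flatness.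

The compounds shown leave open whether anything larger than methyl on the same nitrogen, such as a longer chain or a chain ending in an amine or a carboxylic acid, would also leave growth inhibition in place. They also leave open which of the several differences between the core of compound 1 and the core of compound 3 accounts for the gap between those two cores, since no single-place step connects them.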